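A 4-Bromophenyl Exchange on Compound 3

The compounds below may be only part of what the source reports. "The series", "measured", "known", "first", "only" and "open" are said of these compounds alone.

In a functional assay on U-87MG ATCC cells for inhibition, with U-87 MG (Homo sapiens) as the target, read by MTT assay, with a stated time of 48 h (a higher number here means a weaker inhibitor, a lower number a stronger inhibitor), compound 1 (`COc1cc(/C=N/Nc2nc(-c3ccc(Br)cc3)cs2)cc(Br)c1OC`) reads 27900 nM and compound 2 (`COc1cc(/C=N/Nc2nc(-c3cccc(Br)c3)cs2)cc(Br)c1OC`) reads 86300 nM while compound 3 (`Fc1ccc(/C=N/Nc2nc(-c3ccc(F)c(F)c3)cs2)cc1F`) reads 43900 nM and so lies within the scatter of both others. Compound 4 (`Fc1ccc(/C=N/Nc2nc(-c3ccc(Br)cc3)cs2)cc1F`) puts a 4-bromophenyl in place of the 3,4-difluorophenyl of compound 3, on an aromatic carbon next to the ring nitrogen (4-bromophenyl in place of 3,4-difluorophenyl on an aromatic carbon). Within the data shown here, no measured step makes this exact exchange. Among the measured compounds shown here, the one step that bears on it is a 3.1-fold higher number from compound 1 to compound 2 (0.49 log units; beyond the scatter) and it concerns the bromophenyl group alone. Compound 4 carries the same 4-bromophenyl as compound 1, which reads 27900 nM but differs from compound 4 elsewhere. A slightly lower number is therefore expected, with no shift beyond the scatter. The expected change is a 1.3-fold lower number from compound 3 to compound 4 (0.10 log units; within the scatter) for this exchange. Compound 4 is thus estimated at 35000 nM with 15000 nM to 80000 nM as its expected range.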

Compound 4, half-maximal inhibitory concentration: > 100000 nM
Compound 4 ended at the assay's limit (the forecaster's own chance of this, stated with the estimate: 5%); at least 2.8-fold (0.45 log units) between middle value and limit.
By their numbers in this assay, from the lowest: compounds 1, 3 and 2 (each within the scatter of the next, the first and the last beyond it). At a limit, above all of these: compound 4.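

In this assay, the aromatic carbon next to the ring nitrogen responds to more than the shift of a bromine around the phenyl ring: exchanging 3,4-difluorophenyl for 4-bromophenyl gives an at least 2.2-fold higher number from compound 3 to compound 4 (0.35 log units; beyond the scatter). For compound 4, the reading of > 100000 nM is a limit of the assay and not a number. The full size of this step therefore stays unknown, and only its minimum can be read: the limit of > 100000 nM in this assay, at which 1 of the 4 values shown sits.

The compounds shown leave open whether the step follows from the entry of the bromine or from the loss of the two fluorines, as nothing here separates the two. Also open, from the compounds shown here alone, is how a phenyl ring carrying a chlorine, an amine or a carboxylic acid would read at this position.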